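Fluoromethyl for methyl on the thioamide nitrile series

This account rests on a few compounds, and the source may have more. Where it says the series, first, only, none or still open, it means among the compounds named here.

Measured so far in a functional assay on the whole organism (aorta) with Rattus norvegicus as the target; on this read-out lower numbers stand for smaller maximal responses and higher numbers for larger maximal responses:
- compound 1, `C/N=C(/S)C1=CC(C)(CF)Oc2ccc([N+](=O)[O-])cc21`: 77.1%
- compound 2, `CNC(=O)C1=CC(C)(CF)Oc2ccc([N+](=O)[O-])cc21`: 66%
- compound 3, `CC1(C)C=C(/C(S)=N\CCC#N)c2cc([N+](=O)[O-])ccc2O1`: 78.5%

Compound 3 holds the highest of the three numbers; compound 1 sits within the scatter of it, while compound 2 lies beyond the scatter below it. Among the compounds with values here, the one measured step, a number 11.1 percentage points lower from compound 1 to compound 2 (beyond the scatter), concerns the exchange of the thioamide group for an amide group and does not touch the part changed here.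

Compound 4, `CC1(CF)C=C(/C(S)=N\CCC#N)c2cc([N+](=O)[O-])ccc2O1`, is not yet measured. It differs from compound 3 by fluoro in place of hydrogen on a saturated chain carbon bound to a saturated ring carbon, which cut one bond further out reads methyl to fluoromethyl. Within the data shown here, no measured pair isolates this change: compounds 1 and 3 both carry a thioamide but differ in two places, and their values lie within the scatter of each other. On this basis the expected step of a number 1.5 percentage points lower from compound 3 to compound 4 (within the scatter) in this assay is none beyond the scatter, with wide uncertainty. Compound 4 is therefore estimated at 77%, in the range 65% to 89%.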

Compound 4, intrinsic activity: the largest response reached, in percent of the reference agonist's: 59.6%
Estimate against measurement, compound 4: 17.4 percentage points above; measured number outside the range, below it.
By their numbers in this assay, from the lowest: compounds 4 and 2 (each within the scatter of the next); then compounds 1 and 3 (each within the scatter of the next).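

Fluoro in place of hydrogen on a saturated chain carbon bound to a saturated ring carbon is not a silent change: in this assay it gives a number 18.9 percentage points lower from compound 3 to compound 4 (beyond the scatter). With fluoromethyl held constant, cyanomethyl in place of hydrogen on a saturated chain carbon bound to a double-bonded nitrogen also matters, giving a number 17.5 percentage points lower from compound 1 to compound 4 (beyond the scatter), while replacing the amide group of compound 2 with the nitrile-bearing thioamide group gives only a number 6.4 percentage points lower from compound 2 to compound 4 (within the scatter). Nothing available accounts for the loss of maximal response on fluorination.

Within the data shown here, open is whether the fluoro step depends on the nitrile-bearing chain, since it is seen only in the pair of compound 3 and compound 4. Also open, as far as these compounds go, is how chloromethyl, hydroxymethyl or trifluoromethyl would read at this place.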